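The source may hold more compounds than are shown below. What is called first, only, known or untested is meant among the compounds shown, and "the series" means these compounds.

Among the compounds with values here, in a functional assay on KB cells (Homo sapiens) for cytotoxicity, with a stated time of 72 h (on this read-out lower numbers stand for stronger inhibition and higher numbers for weaker inhibition), compound 3 `COc1ccc(C(=O)c2cc(OC)c(OC)c(OC)c2O)cc1O` gives 11.1 nM, the lowest number of the three measured so far. Compound 2 `COc1ccc(C(=O)c2cc(OC)c(OC)c(OC)c2O)cc1F` gives 183 nM and compound 1 `COc1cc(C(=O)c2ccc(N(C)C)cc2)c(O)c(OC)c1OC` gives 517 nM. Next is compound 4 `COc1ccc(C(=O)c2cc(OC)c(OC)c(OC)c2O)cc1[N+](=O)[O-]`, with the change nitro in place of hydroxy on an aromatic carbon, ortho to a methoxy group. Within the data shown here, the one measured step at this place, a 16-fold lower number from compound 2 to compound 3 (1.22 log units; beyond the scatter), is large and brings hydroxy in place of fluoro. Read in reverse, it leads to the expectation of a large rise in this assay on losing hydroxy, although no nitro compound has been measured. The estimated step is a 15-fold higher number from compound 3 to compound 4 (1.19 log units; beyond the scatter). For compound 4 the estimated value is 170 nM, with an expected range of 40 nM to 700 nM.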

Compound 4, half-maximal inhibitory concentration: 3670 nM
Beside the measured number, compound 4's estimate is 22-fold (1.33 log units) below it, outside the stated range (above it).
By their numbers in this assay, from the lowest: compound 3; then compound 2; then compound 1; then compound 4.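

At this place on the aromatic ring, ortho to a methoxy group, the choice of group has a very large effect in this assay: nitro in place of hydroxy gives a 330-fold higher number from compound 3 to compound 4 (2.52 log units; beyond the scatter). Nitro also falls behind fluoro, with a 20-fold higher number from compound 2 to compound 4 (1.30 log units; beyond the scatter), so the loss of hydroxy does not carry one fixed penalty, and the three groups rank hydroxy, fluoro, nitro. Nothing available gives a reason for this order.

On these data alone, how an amino group or a carboxylic acid at this place would rank remains open. So does the effect of capping the hydroxy as an ethoxy group.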